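The source may report more compounds than this note shows. Statements on the series, on what has been measured and on what is new or still open speak of the compounds shown alone.

Two related compounds have so far been measured in a physicochemical assay for solubility, in phosphate buffer, measured as thermodynamic solubility, at pH 7.4 (on this read-out lower numbers stand for lower solubility and higher numbers for higher solubility), and they sit far apart. Compound 1 `CS(=O)(=O)NC(=O)CCc1cn(C2CCCCC2)nc1-c1ccc(Cl)cc1` gives 200000 nM as a true number. Compound 2 `CNC(=O)CCc1cn(-c2ccc(Br)cc2)nc1-c1ccc(Cl)cc1` gives < 5000 nM in this assay and this is a limit, not a number. Compound 3 `CCS(=O)(=O)NC(=O)CCc1cn(-c2ccc(Br)cc2)nc1-c1ccc(Cl)cc1` keeps the rest of compound 2 and differs in one place: ethylsulfonyl in place of methyl on an amide-type nitrogen describes ethylsulfonyl in place of methyl on an amide-type nitrogen. The expectation rests on compound 1, which also has a sulfonyl group on an amide-type nitrogen and gives 200000 nM in this assay despite differing elsewhere. The expected step of an at least 8.0-fold higher number from compound 2 to compound 3 (0.90 log units; beyond the scatter) is therefore upward and beyond the scatter, although its size stays loose with only a limit at its start. For compound 3 the estimate is 40000 nM with 8000 nM to 200000 nM as the expected range.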

Compound 3, solubility: 10000 nM
The estimate for compound 3 lay 4.0-fold (0.60 log units) above the measured number; the range from low to high includes it.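

In this assay compound 3 gives 10000 nM, a true number, so this pair now has a measured value at one end. Compound 2 gives < 5000 nM, which is a limit and not a number. Ethylsulfonyl in place of methyl on an amide-type nitrogen gives an at least 2.0-fold higher number from compound 2 to compound 3 (0.30 log units; that floor lies within the scatter), and the full size of this step stays unknown because it starts from a limit: the limit of < 5000 nM in this assay, at which 1 of the 3 values shown sits.

The compounds shown do not separate the sulfonyl part of the new group from its ethyl part, as both enter in the same change. They also leave open how a propylsulfonyl or phenylsulfonyl group on this nitrogen would read, or a carboxylic acid in place of the whole (ethylsulfonyl)carbamoyl group.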